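A few compounds are considered here, and "the series" means these few. Any claim that something is new, unique, unknown or untested is made for them only; others in the source may bear on it.

Working notes on the series. For the measured compounds named here, compound 1 `CN[C@@H](CC(C)C)CN(C(=O)[C@@H]1C[C@H]1c1ccccc1)c1ccc(-c2ccccc2)cc1` in a functional assay for agonist activity at G protein-coupled receptor 88 (Homo sapiens), read by HTRF and cAMP accumulation (a higher number here means that more compound is needed for the effect, a lower number that less compound is needed), gives 2 nM, and compound 2 `CC[C@@H](C)[C@H](N)CN(C(=O)[C@@H]1C[C@H]1c1ccccc1)c1ccc(-c2ccccc2)cc1` gives 1.4 nM; the only measured single-point step, a 1.4-fold lower number from compound 1 to compound 2 (0.15 log units; within the scatter), concerns the amine-bearing chain and stays within the scatter. Compound 3 `CC[C@H](C)[C@H](N)CN(C(=O)[C@@H]1C[C@H]1c1cccc(OC)c1)c1ccc(-c2ccccc2)cc1` gives 3000 nM, the highest of the three numbers, far beyond the scatter from compound 2 and from compound 1; compound 3 is the only one of the three carrying a group on the phenyl ring attached to the cyclopropane, so the two values of compound 2 and compound 3 are all that show what a substituent there does.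

Compound 4 `CC[C@H](C)[C@H](N)CN(C(=O)[C@@H]1C[C@H]1c1ccc(F)c(F)c1)c1ccc(-c2ccccc2)cc1` is the next member: 3,4-difluorophenyl in place of 3-methoxyphenyl on a saturated ring carbon. Going by the values given here, no measured step touches this ring, so the expectation rests on compound 2 at 1.4 nM with the bare ring and on compound 3 at 3000 nM. A lowering step a 20-fold lower number from compound 3 to compound 4 (1.30 log units; beyond the scatter) is expected, with wide uncertainty, since the two fluorines may behave unlike the methoxy. For compound 4 the estimate is 150 nM, in the range 5 nM to 3000 nM.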

Compound 4, half-maximal effective concentration: 720 nM
Estimate against measurement, compound 4: 4.8-fold (0.68 log units) below, within the range that was stated.
By their numbers in this assay, from the lowest: compounds 2 and 1 (each within the scatter of the next); then compound 4; then compound 3.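

For the compounds shown here, this ring substituent can be changed with a measurable effect in this assay: going from 2-(3-methoxyphenyl)cyclopropyl to 2-(3,4-difluorophenyl)cyclopropyl gives a 4.2-fold lower number from compound 3 to compound 4 (0.62 log units; beyond the scatter), the first measured single-place step at this position. The two groups count the same 8 heavy atoms, while the hydrogen-bond acceptor count falls from 1 to 0, so a modest but real difference separates two substituted rings of equal heavy-atom count. No available measurement accounts for the step.

Still open, from the compounds shown here alone, is what the bare phenyl gives on the chain shared by compound 3 and compound 4, as compound 2 differs from them in the chain as well as in the ring. Also open, going by these compounds, is how 3-fluorophenyl, 4-fluorophenyl or 3-hydroxyphenyl would fall relative to these two groups.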